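Ethynyl in place of thiophen-3-yl on compound 3

A few compounds are considered here, and "the series" means these few. Any claim that something is new, unique, unknown or untested is made for them only; others in the source may bear on it.

Measured in a functional assay on HeLa S3 cells (Homo sapiens) for antiproliferative activity, read by XTT assay, with a stated time of 72 h; a higher number here means a weaker inhibitor, a lower number a stronger inhibitor:
- compound 1 `C#Cc1cn([C@@H]2O[C@H](CO)[C@@H](O)[C@H]2O)c2ncnc(OC)c12`: 1730 nM
- compound 2 `CSc1ncnc2c1c(-c1cccs1)cn2[C@@H]1O[C@H](CO)[C@@H](O)[C@H]1O`: 1960 nM
- compound 3 `CSc1ncnc2c1c(-c1ccsc1)cn2[C@@H]1O[C@H](CO)[C@@H](O)[C@H]1O`: > 20000 nM

Compound 3 has no exact number, since its > 20000 nM is only a limit of the assay. Compound 4 `C#Cc1cn([C@@H]2O[C@H](CO)[C@@H](O)[C@H]2O)c2ncnc(SC)c12` differs from it by having ethynyl in place of thiophen-3-yl on an aromatic carbon.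

Going by the values given here, the one measured step on this carbon is an at least 10-fold higher number from compound 2 to compound 3 (1.00 log units; beyond the scatter), with thiophen-3-yl in place of thiophen-2-yl. It lies beyond the scatter, so the group held here can matter a great deal. Among the compounds with values here, no step with ethynyl has been measured. Compound 1 also carries ethynyl on this carbon but differs from compound 4 elsewhere on the shared core. In this assay compound 1 gives 1730 nM, and this value points to a large move towards a lower number, meaning a stronger inhibitor.

The expected change is an at least 13-fold lower number from compound 3 to compound 4 (1.12 log units; beyond the scatter). For compound 4 the estimate is 1500 nM, with an expected range of 300 nM to 8000 nM.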

Compound 4, half-maximal inhibitory concentration: 110 nM
Compound 4: middle estimate off by 14-fold (1.13 log units), on the high side; measured number below the stated range.
By their numbers in this assay, from the lowest: compound 4; then compounds 1 and 2 (each within the scatter of the next). At a limit, above all of these: compound 3.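

In this assay, ethynyl on this carbon outperforms both thiophene groups, giving an 18-fold lower number from compound 2 to compound 4 (1.25 log units; beyond the scatter) and an at least 180-fold lower number from compound 3 to compound 4 (2.25 log units; beyond the scatter). Compound 3 has only a limit, so the second of these steps is a minimum: the limit of > 20000 nM in this assay, at which 1 of the 4 values shown sits. The group on the other aromatic carbon also matters, because with ethynyl held constant, methylsulfanyl in place of methoxy gives a 16-fold lower number from compound 1 to compound 4 (1.20 log units; beyond the scatter), so the sulfur-linked group brings a large change of its own.

On these data alone, whether ethyl or a longer chain on the first carbon would retain this gain remains open, which leaves the importance of the triple bond itself unsettled. As far as these compounds go, it is also open whether an amine could replace methylsulfanyl, and whether the methoxy-to-methylsulfanyl change would be as large with a thiophene group in place of ethynyl.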